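The source may report more compounds than this note shows. Statements on the series, on what has been measured and on what is new or still open speak of the compounds shown alone.

Compound 1 `COc1cccc(-n2cc(CO/N=C3\CC[C@]4(C)[C@@H](CC/C=C(\C)CC/C=C(\C)CCC=C(C)C)[C@](C)(O)CC[C@H]4C3(C)C)nn2)c1` gives 30500 nM in a functional assay on DU-145 cells (Homo sapiens) for cytotoxicity, read by MTT assay, with a stated time of 48 h; a lower number here means a stronger inhibitor, a higher number a weaker inhibitor. Compound 2 `CC(C)=CCC/C(C)=C/CC/C(C)=C/CC[C@@H]1[C@@]2(C)CC/C(=N\OCc3cn(-c4c(Cl)cc([N+](=O)[O-])cc4Cl)nn3)C(C)(C)[C@@H]2CC[C@@]1(C)O` gives 16400 nM in this assay, and compound 3 `COc1cccc(-n2cc(COc3ccc(/C=C4\C[C@]5(C)[C@@H](CC/C=C(\C)CC/C=C(\C)CCC=C(C)C)[C@](C)(O)CC[C@H]5C(C)(C)C4=O)cc3)nn2)c1` gives 14500 nM. Compound 3 thus has the lowest number of the three, although compound 2 sits within the scatter of it; only compound 1 lies beyond. Compound 4 `CC(C)=CCC/C(C)=C/CC/C(C)=C/CC[C@@H]1[C@@]2(C)C/C(=C\c3ccc(OCc4cn(-c5cccc([N+](=O)[O-])c5)nn4)cc3)C(=O)C(C)(C)[C@@H]2CC[C@@]1(C)O` differs from compound 3 by nitro in place of methoxy on an aromatic carbon. For the measured compounds named here, the one measured step that touches the aromatic ring on the aromatic nitrogen, a 1.9-fold lower number from compound 1 to compound 2 (0.27 log units; within the scatter), also brought in a nitro among other changes and stayed within the scatter. Compound 4 is therefore expected to show no step beyond the scatter, a 1.2-fold lower number from compound 3 to compound 4 (0.08 log units; within the scatter). Compound 4 in this assay is estimated at 12000 nM, between 4000 nM and 40000 nM.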

Compound 4, half-maximal inhibitory concentration: 46400 nM
Beside the measured number, compound 4's estimate is 3.9-fold (0.59 log units) below it, outside the stated range (above it).
By their numbers in this assay, from the lowest: compounds 3, 2, 1 and 4 (each within the scatter of the next, the first and the last beyond it).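

In this assay, nitro in place of methoxy on an aromatic carbon gives a step beyond the scatter, a 3.2-fold higher number from compound 3 to compound 4 (0.51 log units; beyond the scatter), so this ring position does respond to the change. The earlier change on this ring, 2,6-dichloro-4-nitrophenyl in place of 3-methoxyphenyl, stayed within the scatter and could not show this. Nothing measured here accounts for the step.

From the compounds shown here alone, whether an amine or a carboxylic acid at this position would stay close to compound 3 or to compound 4 remains open. So does whether 3-nitrophenyl in place of 3-methoxyphenyl would give a like step on the core of compound 1.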